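Swapping an imidazole arm for a morpholine amide

The compounds below may be only part of what the source reports. "The series", "measured", "known", "first", "only" and "open" are said of these compounds alone.

Compound 1 (`CC(Oc1nn(-c2ccccc2F)c2ccc(F)cc12)C(=O)N1CCOCC1`): 2 h
Compound 2 (`Fc1ccc2c(c1)c(OCCn1ccnc1)nn2-c1ccccc1F`): 1.1 h

Only these two compounds have been measured so far in an ADME assay on the whole organism (strain Sprague-Dawley) for metabolic stability, with Rattus norvegicus as the target, read by LC-MS; on this read-out lower numbers stand for a shorter-lived compound and higher numbers for a longer-lived compound. Compound 2 stands at 1.1 h and compound 1 at 2 h, so the pair lies within the usual scatter of repeated measurements, and neither can be called the longer-lived.

Compound 3 (`O=C(COc1nn(-c2ccccc2F)c2ccc(F)cc12)N1CCOCC1`) is the next to be measured. It differs from compound 2 in one place, on a saturated chain carbon bound to an oxygen on an aromatic ring, where (morpholin-4-yl)carbonyl takes the place of (1H-imidazol-1-yl)methyl ((morpholin-4-yl)carbonyl in place of (1H-imidazol-1-yl)methyl on a saturated chain carbon bound to an oxygen on an aromatic ring).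

Among the compounds with values here, no measured step shows what this exchange does in this assay, so the expectation is a cautious one. Within the data shown here, the only guide is the other measured number, from compound 1 (2 h), which suggests a small rise at most. The expected change is a 1.5-fold higher number from compound 2 to compound 3 (0.19 log units; within the scatter), upward in direction but not beyond the scatter. The estimated half-life of compound 3 is 1.7 h (range 0.7 h to 4 h).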

Compound 3, half-life: 1.6 h
The estimate for compound 3 lay 1.1-fold (0.03 log units) above the measured number; low and high end bracket the measured number.
By their numbers in this assay, from the lowest: compounds 2, 3 and 1 (each within the scatter of the next).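

In this assay, within the data shown here, the first direct reading of this exchange, (morpholin-4-yl)carbonyl in place of (1H-imidazol-1-yl)methyl on a saturated chain carbon bound to an oxygen on an aromatic ring gives a 1.5-fold higher number from compound 2 to compound 3 (0.16 log units; within the scatter) and stays within the scatter, so the two arms cannot be told apart here, although one carries a five-membered aromatic ring and the other a six-membered non-aromatic ring and a carbonyl. The methyl on the chain carbon can now be read as well: hydrogen in its place gives a 1.3-fold lower number from compound 1 to compound 3 (0.10 log units; within the scatter), again within the scatter, so the morpholine amide arm shows no readable dependence on that methyl in this small set. Nothing available offers an explanation for either step.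

As far as these compounds go, it remains open whether any group at this place can move the half-life beyond the scatter, for example a carboxylic acid, a piperazine amide or a longer chain ending in the same morpholine amide. Also open, from the compounds shown here alone, is how a methyl on the chain of the 2-(1H-imidazol-1-yl)ethyl arm would read, since the methyl step is known only for the morpholine amide arm.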